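The compounds below may be only part of what the source reports. "The series", "measured", "known", "first", "only" and "open" are said of these compounds alone.

Compound 1, `O=C(Nc1ccc(OC(F)(F)F)cc1)c1cc(=O)[nH]c2cc(Br)ccc12`: in a functional assay on KYSE-70 cells for antiproliferative activity against KYSE-70 cell line (Homo sapiens), read by MTT assay, with a stated time of 72 h (on this read-out higher numbers stand for weaker inhibition and lower numbers for stronger inhibition), compound 1 gives > 20000 nM, which is a limit of the assay.
Compound 2, `O=C(Nc1cccc(C(F)(F)F)c1)c1cc(=O)[nH]c2cc(Br)ccc12`: in this assay compound 2 gives > 20000 nM, again a limit of the assay.
Compound 3, `O=C(Nc1cccc(F)c1)c1cc(=O)[nH]c2cc(-c3ccccc3)ccc12`: in this assay compound 3 gives > 20000 nM, once more a limit of the assay.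

Compound 3 therefore stands nowhere distinct on the numbers shown: all three measured compounds sit at the same limit, so no order among them can be read and no step between measured compounds is available. For the measured compounds named here, the only evidence is the limit of > 20000 nM in this assay, at which 3 of the 3 values shown sit, which says that every value recorded so far is a limit rather than a number.

Compound 4, `O=C(Nc1cccc(F)c1)c1cc(=O)[nH]c2cc(-c3ccncc3)ccc12`, differs from compound 3 in one place: pyridin-4-yl in place of phenyl on an aromatic carbon. Going by the values given here, nothing measured here says how such a change moves the read-out, since no pair of measured compounds differing in one place exists. The expectation for compound 4 is thus that the step from compound 3, a step that the limit leaves unreadable from compound 3 to compound 4, stays within the scatter, with a real chance that only a limit is reported again. Compound 4 is estimated at 30000 nM, within a range from 8000 nM to 100000 nM.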

Compound 4, half-maximal inhibitory concentration: > 20000 nM
Compound 4 was reported as a limit; the forecaster's own chance of this, stated with the estimate: 70%; the middle value does not contradict the limit.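

For the compounds shown here, compound 3 and compound 4 both stand as limits of the assay, so the exchange of phenyl for pyridin-4-yl gives no step that can be read. The compounds shown leave open how any of them ranks against the others and which change, if any, would yield a measurable number, as only one result is recorded: the limit of > 20000 nM in this assay, at which 4 of the 4 values shown sit.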